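The source may hold more compounds than are shown below. What is called first, only, known or untested is meant among the compounds shown, and "the series" means these compounds.

Compound 1 `N#Cc1cnc(NCc2cnccc2C(F)(F)F)cc1NC[C@H]1CC[C@H](O)CC1`: 50 nM
Compound 2 `N#Cc1cnc(NCc2cnccc2C(F)(F)F)cc1N[C@H]1CC[C@@H](c2nc[nH]n2)CC1`: 34 nM

In an assay on isolated protein for inhibition of protein kinase C theta type (Homo sapiens), read by TR-FRET, with a stated time of 2 h (a lower number here means a stronger inhibitor, a higher number a weaker inhibitor), compound 1 gives 50 nM, the higher of the two numbers, and compound 2 gives 34 nM; these two values lie within the usual scatter of each other, so neither compound can be called the stronger inhibitor. Compound 3 `CC1(C)C[C@@H](Nc2cc(NCc3cnccc3C(F)(F)F)ncc2C#N)CC[C@@H]1O` differs from compound 1 in one place: 4-hydroxy-3,3-dimethylcyclohexyl in place of (4-hydroxycyclohexyl)methyl on a nitrogen on an aromatic ring. Within the data shown here, no measured pair shows the effect of this change in this assay, so only a small step is expected, in either direction or none beyond the scatter: a 1.3-fold lower number from compound 1 to compound 3 (0.10 log units; within the scatter). Compound 3 is estimated at 40 nM, with a likely range from 12 nM to 130 nM.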

Compound 3, half-maximal inhibitory concentration: 120 nM
The estimate for compound 3 lay 3.0-fold (0.48 log units) below the measured number; the range from low to high includes it.
By their numbers in this assay, from the lowest: compounds 2 and 1 (each within the scatter of the next); then compound 3.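

At this position, on a nitrogen on an aromatic ring, the choice of group can matter: 4-hydroxy-3,3-dimethylcyclohexyl in place of (4-hydroxycyclohexyl)methyl gives a 2.4-fold higher number from compound 1 to compound 3 (0.38 log units; beyond the scatter) in this assay, a modest step towards a weaker inhibitor. This single step combines two structural differences, the carbon link that leaves and the two methyl groups that enter, and cannot separate them. Nothing available explains the step.

Still open, as far as these compounds go, is how 4-hydroxycyclohexyl, attached directly to the nitrogen without the two methyl groups, would compare. So is the effect of an amine in place of the hydroxyl.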